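Methyl for Methoxy on the Amide Aryl of Compound 3

The source may hold more compounds than are shown below. What is called first, only, known or untested is meant among the compounds shown, and "the series" means these compounds.

In an assay on MDA-MB-231 cells for binding affinity to C-X-C chemokine receptor type 4 (Homo sapiens), read by immunofluorescence and microscopy, with stated times of 10 min and 30 min (on this read-out higher numbers stand for an effect only at larger amounts of compound and lower numbers for an effect already at smaller amounts), compound 1 `Cc1ccc(S(=O)(=O)NCc2ccc(CNC(=O)c3ccc([N+](=O)[O-])cc3)cc2)cc1` gives 10 nM and compound 2 `COc1cccc(C(=O)NCc2ccc(CNS(=O)(=O)c3ccc(C)cc3)cc2)c1` gives 10 nM, and between them no change at the digits printed from compound 1 to compound 2 (within the scatter). Compound 3 `COc1ccccc1C(=O)NCc1ccc(CNS(=O)(=O)c2ccc(C)cc2)cc1` gives 100 nM and stands highest of the three numbers. The two steps that lead to it are a 10-fold higher number from compound 1 to compound 3 (1.00 log units; beyond the scatter) and a 10-fold higher number from compound 2 to compound 3 (1.00 log units; beyond the scatter), each a modest rise beyond the scatter.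

Compound 4 `Cc1ccc(S(=O)(=O)NCc2ccc(CNC(=O)c3ccccc3C)cc2)cc1` keeps the core of compound 3 and differs from it only in methyl in place of methoxy on an aromatic carbon, so that (2-methoxyphenyl)carbonyl becomes (2-methylphenyl)carbonyl. No measured step touches this exact exchange: the steps shown compare a 2-methoxyphenyl with a 4-nitrophenyl or a 3-methoxyphenyl on the carbonyl carbon, not a methoxy with a methyl in the same place. The data thus give no direct guide, and the expected step, no change at the digits printed from compound 3 to compound 4 (within the scatter), is estimated to lie within the scatter, with wide uncertainty. Compound 4 is therefore expected to give about 100 nM, in a range from 30 nM to 300 nM.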

Compound 4, effective concentration (reported as EC, without a stated level of effect): 100 nM
The estimate for compound 4 equals the measured number at the digits printed; the measured number falls inside the stated range.
By their numbers in this assay, from the lowest: compounds 1 and 2 (each within the scatter of the next); then compounds 3 and 4 (each within the scatter of the next).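

In this assay there is no change at the digits printed from compound 3 to compound 4 (within the scatter), so at this place, ortho to a large group, methoxy can give way to methyl, with the loss of its oxygen and its one hydrogen-bond acceptor, without any shift in the number. The other two steps hold as well, with a 10-fold higher number from compound 2 to compound 4 (1.00 log units; beyond the scatter) and a 10-fold higher number from compound 1 to compound 4 (1.00 log units; beyond the scatter), so the 2-methylphenyl compound stands with the 2-methoxyphenyl compound, apart from the 3-methoxyphenyl and 4-nitrophenyl compounds. Nothing available explains why these numbers fall as they do.

On these data alone, whether this place also accepts an amine, a carboxylic acid or a longer chain such as propyl remains open. The compounds shown also leave open how a plain phenyl, with only hydrogen at this place, would compare with compound 3 and compound 4.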